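This account rests on a few compounds, and the source may have more. Where it says the series, first, only, none or still open, it means among the compounds named here.

The three measured compounds share one core and differ only in the aryl group on the carbon with a double bond to nitrogen. Compound 1 `O=C(CSc1nnc(-c2ccncc2)o1)N/N=C/c1ccc(Br)cc1` gives 19100 nM in a functional assay on MCF7 cells (Homo sapiens) for cytotoxicity, read by MTT assay, with a stated time of 48 h; on this read-out lower numbers stand for stronger inhibition and higher numbers for weaker inhibition. Compound 2 `O=C(CSc1nnc(-c2ccncc2)o1)N/N=C/c1ccc([N+](=O)[O-])cc1` gives 31800 nM in this assay, and compound 3 `O=C(CSc1nnc(-c2ccncc2)o1)N/N=C/c1ccc(O)cc1` gives 11700 nM in this assay. Compound 3 has the lowest of the three numbers: the steps leading to it were a 2.7-fold lower number from compound 2 to compound 3 (0.43 log units; beyond the scatter) and a 1.6-fold lower number from compound 1 to compound 3 (0.21 log units; within the scatter), so compound 3 and compound 1 cannot be separated on these numbers. The remaining step was a 1.7-fold higher number from compound 1 to compound 2 (0.22 log units; within the scatter).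

Compound 4 `O=C(CSc1nnc(-c2ccncc2)o1)N/N=C/c1cc(Cl)cc(Cl)c1O` carries 3,5-dichloro-2-hydroxyphenyl in place of 4-hydroxyphenyl on a carbon with a double bond to nitrogen. Among the measured compounds shown here, no measured step exchanges one aryl group for another carrying two chlorines, so nothing bears on this change directly. For the measured compounds named here, the only guidance is that every measured exchange of one substituent for another on the aromatic ring moved the number by a small amount, two of them within the scatter and one only modestly beyond it. The change is therefore expected to be small, and compound 4 is expected to show a 1.3-fold lower number from compound 3 to compound 4 (0.11 log units; within the scatter). The estimated value for compound 4 in this assay is 9000 nM, within a range from 3000 nM to 27000 nM.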

Compound 4, half-maximal inhibitory concentration: 5920 nM
Compound 4: middle estimate off by 1.5-fold (0.18 log units), on the high side; low and high end bracket the measured number.
By their numbers in this assay, from the lowest: compounds 4, 3, 1 and 2 (each within the scatter of the next, the first and the last beyond it).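

Among the compounds shown here, compound 4 is the first compound at this position to separate from the 4-bromophenyl compound, with a 3.2-fold lower number from compound 1 to compound 4 (0.51 log units; beyond the scatter) in this assay, and it also stands clear of the 4-nitrophenyl compound, with a 5.4-fold lower number from compound 2 to compound 4 (0.73 log units; beyond the scatter); compound 3 had been separated only from the latter. Against the closest earlier compound, however, the exchange of 4-hydroxyphenyl for 3,5-dichloro-2-hydroxyphenyl gives a 2.0-fold lower number from compound 3 to compound 4 (0.30 log units; within the scatter), so adding the two chlorines and changing the place of the hydroxy group together do not distinguish compound 4 from compound 3. Nothing measured here accounts for the size of any of these steps.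

The compounds shown leave open how much of the separation from compound 1 and compound 2 belongs to the chlorines and how much to the hydroxy group, since these enter together and no aryl group here carries the two chlorines without a hydroxy group. They also leave open how an amine or a carboxylic acid on the aromatic ring would read in this assay.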